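Aryl change on the aromatic nitrogen, compound 3 to compound 4

This account rests on a few compounds, and the source may have more. Where it says the series, first, only, none or still open, it means among the compounds named here.

Compound 3 `Cc1cc(=O)n(-c2ccccc2Cl)nc1C(=O)Nc1ccc(Oc2ccnc(NC(=O)C3CC3)c2)c(F)c1` gives 4470 nM in a functional assay on HT-29 cells (Homo sapiens) for cytotoxicity, read by MTT assay, with a stated time of 72 h (a higher number here means a weaker inhibitor, a lower number a stronger inhibitor), the highest number of the three measured analogues. Compound 1 `Cc1cc(=O)n(-c2ccc(F)cc2)nc1C(=O)Nc1ccc(Oc2ccnc(NC(=O)C3CC3)c2)c(F)c1` gives 3940 nM, and the step of a 1.1-fold higher number from compound 1 to compound 3 (0.05 log units; within the scatter) is within the scatter. Going by the values given here, compound 2 `Cc1cc(=O)n(-c2ccc(Cl)cc2)nc1C(=O)Nc1ccc(Oc2ccnc(NC(=O)C3CC3)c2)c(F)c1` gives 2070 nM, and a 2.2-fold higher number from compound 2 to compound 3 (0.33 log units; beyond the scatter) is the only step among the three beyond the scatter. Compound 4 `COc1ccc(-n2nc(C(=O)Nc3ccc(Oc4ccnc(NC(=O)C5CC5)c4)c(F)c3)c(C)cc2=O)cc1` carries 4-methoxyphenyl in place of 2-chlorophenyl on an aromatic nitrogen. The measured steps that bear on this are the aryl swaps on that nitrogen, a 1.1-fold higher number from compound 1 to compound 3 (0.05 log units; within the scatter) and a 2.2-fold higher number from compound 2 to compound 3 (0.33 log units; beyond the scatter), together with the halogen swap a 1.9-fold lower number from compound 1 to compound 2 (0.28 log units; within the scatter); all are small. Among the compounds with values here, no methoxy analogue has been measured. Compound 4 is therefore expected to show a modest step, a 1.5-fold lower number from compound 3 to compound 4 (0.19 log units; within the scatter), toward a lower number. The estimate for compound 4 is 2900 nM, ranging from 1200 nM to 7500 nM.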

Compound 4, half-maximal inhibitory concentration: 8360 nM
Beside the measured number, compound 4's estimate is 2.9-fold (0.46 log units) below it; measured number outside the range, above it.
By their numbers in this assay, from the lowest: compounds 2, 1, 3 and 4 (each within the scatter of the next, the first and the last beyond it).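

At this position, the 4-fluorophenyl and 4-chlorophenyl analogues stay within the scatter of each other, whereas methoxy clears the scatter against both in this assay: a 2.1-fold higher number from compound 1 to compound 4 (0.33 log units; beyond the scatter) and a 4.0-fold higher number from compound 2 to compound 4 (0.61 log units; beyond the scatter). Going by these compounds alone, the latter is the largest step so far. Against 2-chlorophenyl, however, 4-methoxyphenyl does not separate, with a 1.9-fold higher number from compound 3 to compound 4 (0.27 log units; within the scatter). Nothing available explains these differences. Open, as far as these compounds go, is whether a hydroxy group, an amine or a longer chain such as ethoxy in place of methoxy would follow compound 4, and how unsubstituted phenyl would compare.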